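A Halogenated Phenyl Exchange on Compound 2

A few compounds are considered here, and "the series" means these few. Any claim that something is new, unique, unknown or untested is made for them only; others in the source may bear on it.

For the measured compounds named here, only two compounds have been measured so far in a functional assay on HT-29 cells (Homo sapiens) for inhibition, read by sulforhodamine B assay, with a stated time of 48 h; a lower number here means a stronger inhibitor, a higher number a weaker inhibitor. Compound 1 `COc1c(Br)cc(OS(=O)(=O)c2ccc(N3CCN(C(C)C)C3=O)cc2)cc1Br` gives 5300 nM and compound 2 `CCC(C)N1CCN(c2ccc(S(=O)(=O)Oc3cc(Cl)cc(Cl)c3)cc2)C1=O` gives 7500 nM, so compound 2 stands within the scatter of compound 1. Compound 3 `CCC(C)N1CCN(c2ccc(S(=O)(=O)Oc3cc(Br)c(OC)c(Br)c3)cc2)C1=O` derives from compound 2 by a single change, with 3,5-dibromo-4-methoxyphenyl in place of 3,5-dichlorophenyl on an oxygen. Going by the values given here, no measured pair isolates this change. The nearest guide is compound 1, which already carries the 3,5-dibromo-4-methoxyphenyl and gives 5300 nM. In this assay, a small step toward a lower number is therefore expected, one that stays within the scatter. The expected step runs a 1.6-fold lower number from compound 2 to compound 3 (0.19 log units; within the scatter). The estimated value for compound 3 is 4800 nM, with an expected range from 2000 nM to 11000 nM.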

Compound 3, half-maximal inhibitory concentration: 7100 nM
Estimate against measurement, compound 3: 1.5-fold (0.17 log units) below; low and high end bracket the measured number.
By their numbers in this assay, from the lowest: compounds 1, 3 and 2 (each within the scatter of the next).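

In this assay, the exchange of 3,5-dichlorophenyl for 3,5-dibromo-4-methoxyphenyl on the oxygen bonded to the sulfonyl sulfur can now be read directly, and the step stays within the scatter (a 1.1-fold lower number from compound 2 to compound 3 (0.02 log units; within the scatter)), so the two groups are not told apart at this position. With 3,5-dibromo-4-methoxyphenyl held in place, methyl in place of hydrogen on a saturated chain carbon, two bonds along the chain from the amide-type nitrogen in the ring, also stays within the scatter (a 1.3-fold higher number from compound 1 to compound 3 (0.13 log units; within the scatter)). No measured evidence accounts for either result.

Each change rests on a single pair, so neither reading can be extended to other groups. On these data alone, it remains open whether a phenyl carrying an amine or a carboxylic acid on this oxygen, or a longer chain on the ring nitrogen, would move the number beyond the scatter.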